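The source may report more compounds than this note shows. Statements on the series, on what has been measured and on what is new or still open speak of the compounds shown alone.

Compound 1, `O=C(C1CCN(c2ccccc2)CC1)N1N=CC[C@H]1c1ccccc1`, sits at 6.3 in a physicochemical assay for lipophilicity, read by HPLC, measured as chromatographic lipophilicity, at pH 7.4 (a lower number here means a more polar compound, a higher number a more lipophilic compound), level with compound 2, `O=C(C1CCN(c2ccccc2)CC1)N1N=CCC1c1ccccc1`, which gives 6.3. Among the measured compounds shown here, the step of no change at the digits printed from compound 1 to compound 2 (within the scatter) rests on the fact that one of compounds 1 and 2 is drawn with a defined configuration and the other without, at the place where they differ and is the only measured step. Compound 3, `O=C(C1CCN(c2cccnn2)CC1)N1N=CC[C@H]1c1ccccc1`, differs from compound 1 by pyridazin-3-yl in place of phenyl on an amine nitrogen in a ring. For the measured compounds named here, no measured step covers an exchange of one aromatic ring for another; the step from compound 1 to compound 2 leaves the atoms unchanged and so says nothing about this change. With two hydrogen-bond acceptors entering where phenyl carried none, a clear fall in this assay is expected, a number 1.70 log units lower from compound 1 to compound 3 (beyond the scatter). Compound 3 is therefore estimated at 4.6, with a range from 3.8 to 5.4.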

Compound 3, distribution coefficient: 3.4
Compound 3: middle estimate off by 1.20 log units, on the high side, outside the stated range (below it).
By their numbers in this assay, from the lowest: compound 3; then compounds 1 and 2 (each within the scatter of the next).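

In this assay, pyridazin-3-yl in place of phenyl on an amine nitrogen in a ring gives a number 2.90 log units lower from compound 1 to compound 3 (beyond the scatter) in the series. This position therefore responds strongly to an exchange of one aromatic ring for another, which the earlier pair, differing only in drawn configuration, could not show. Nothing recorded for the series accounts for the size of this step.

Open, on these data alone, is whether a pyridine or pyrimidine ring at this position would give a step of similar size. Also open, as far as these compounds go, is how a phenyl ring carrying an amine or a carboxylic acid would read here.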